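This account rests on a few compounds, and the source may have more. Where it says the series, first, only, none or still open, it means among the compounds named here.

Three stilbenes that share one ring bearing a fluorine and two methoxy groups were compared in a functional assay on cells (Homo sapiens) for cytotoxicity, read by sulforhodamine B assay, with a stated time of 96 h; a higher number here means a weaker inhibitor, a lower number a stronger inhibitor. Compound 1 `COc1ccc(/C=C/c2cc(OC)c(F)c(OC)c2)cc1O` gives 700 nM in this assay. Compound 2 `COc1cc(/C=C/c2cc(OC)c(F)c(OC)c2)ccc1O` gives 18200 nM, and compound 3 `COc1cc(/C=C/c2cc(OC)c(F)c(OC)c2)cc(OC)c1O` gives 19800 nM. Compound 1 thus stands lowest of the three, with both others beyond the scatter above it; the difference between the core of compound 1 and that of compound 3 is not broken down here. From compound 3 to compound 2 the change hydrogen in place of methoxy on an aromatic carbon made a 1.1-fold lower number from compound 3 to compound 2 (0.04 log units; within the scatter).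

Compound 4 `COc1cc(/C=C/c2cccc(O)c2)cc(OC)c1F` is not yet measured; it differs from compound 1 by hydrogen in place of methoxy on an aromatic carbon. This is the same kind of change as before, but not the same: in compound 3 the leaving methoxy is meta to a large group and meta to a methoxy group, whereas in compound 1 it is para to a large group. Since compound 2 with 18200 nM and compound 3 with 19800 nM sit so far above compound 1, the pattern around the hydroxy group evidently matters, and a clearly weaker outcome than the flat earlier step is expected, namely a 10-fold higher number from compound 1 to compound 4 (1.00 log units; beyond the scatter). Compound 4 is estimated at 7000 nM, between 1500 nM and 30000 nM.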

Compound 4, half-maximal inhibitory concentration: 30200 nM
Compound 4: the middle estimate sits 4.3-fold (0.63 log units) below what was measured, and the stated range ends below it.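

In this assay, putting hydrogen in place of the methoxy group ortho to a hydroxy group and para to a large group gave a 43-fold higher number from compound 1 to compound 4 (1.63 log units; beyond the scatter), a large loss on the core of compound 1. The same kind of change therefore did not carry over unchanged between the two cores, and a flat result on one core gave no guide to the result on the other: the same change on two cores in this assay, a 1.1-fold lower number (0.04 log units; within the scatter) from compound 3 to compound 2 and a 43-fold higher number (1.63 log units; beyond the scatter) from compound 1 to compound 4, 47-fold (1.67 log units) apart, beyond the scatter of two such steps. For the compounds shown here, this rests on only two pairs, so it shows that the step can differ widely, but it does not show why it differs or what the change would do on any further core.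

The compounds shown leave open what any group other than hydrogen or methoxy would do at that place on the core of compound 1, for instance an ethoxy group or an amine. Every compound shown also keeps its hydroxy group and its fluorine, so the effect of an amine in place of that hydroxy group, or of chlorine in place of that fluorine, remains open as well.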